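Piperidine sulfonamide series: permeability of compound 4

A few compounds are considered here, and "the series" means these few. Any claim that something is new, unique, unknown or untested is made for them only; others in the source may bear on it.

Within the data shown here, compound 3 `CC(C)S(=O)(=O)N1CCC(CN(C2Cc3cc(C#N)ccc3N(Cc3cncn3C)C2)S(=O)(=O)c2ccccn2)CC1` gives 0.1 10^-6 cm/s in an ADME assay on Caco-2 cells (Homo sapiens) for permeability, in the apical to basolateral direction (a lower number here means that the compound crosses the layer more slowly, a higher number that the compound crosses the layer faster), the lowest of the three numbers measured so far. Compound 1 `CCC(=O)N1CCC(CN(C2Cc3cc(C#N)ccc3N(Cc3cncn3C)C2)S(=O)(=O)c2ccccn2)CC1` gives 0.5 10^-6 cm/s and compound 2 `CC(C)C(=O)N1CCC(CN(C2Cc3cc(C#N)ccc3N(Cc3cncn3C)C2)S(=O)(=O)c2ccccn2)CC1` gives 0.5 10^-6 cm/s; the step of no change at the digits printed from compound 1 to compound 2 (within the scatter) shows that enlarging the acyl chain left the number unchanged, whereas a 5.0-fold lower number from compound 1 to compound 3 (0.70 log units; beyond the scatter) and a 5.0-fold lower number from compound 2 to compound 3 (0.70 log units; beyond the scatter) show that exchanging the acyl group for a sulfonyl group lowered it.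

Compound 4 `Cn1cncc1CN1CC(N(CC2CCN(S(=O)(=O)c3ccccc3)CC2)S(=O)(=O)c2ccccn2)Cc2cc(C#N)ccc21` differs from compound 3 by phenyl in place of isopropyl on a sulfonyl sulfur. Among the measured compounds shown here, no measured step exchanges one sulfonyl substituent for another; the only step within the sulfonyl-free part of the series, no change at the digits printed from compound 1 to compound 2 (within the scatter), concerns a change in a chain and stays within the scatter. The two sulfonyl-bearing compounds 3 and 4 are therefore compared without a direct precedent, and the expectation is that the number of compound 4 stays in the low region defined by compound 3, with at most a small step of a 1.5-fold higher number from compound 3 to compound 4 (0.18 log units; within the scatter) that is not expected to exceed the scatter. Compound 4 is estimated to give 0.15 10^-6 cm/s, with a range from 0.05 10^-6 cm/s to 0.5 10^-6 cm/s.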

Compound 4, apparent permeability: 0.1 10^-6 cm/s
The estimate for compound 4 lay 1.5-fold (0.18 log units) above the measured number; the range from low to high includes it.
By their numbers in this assay, from the lowest: compounds 3 and 4 (each within the scatter of the next); then compounds 1 and 2 (each within the scatter of the next).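

On a sulfonyl sulfur whose other neighbour is the sulfonamide nitrogen in a ring, the series now has its first exchange of one sulfonyl substituent for another: phenyl in place of isopropyl brings in a six-membered aromatic ring of carbon only, and in this assay the result is no change at the digits printed from compound 3 to compound 4 (within the scatter). The gap to the acyl compounds recurs with this second sulfonyl group, at a 5.0-fold lower number from compound 2 to compound 4 (0.70 log units; beyond the scatter) and a 5.0-fold lower number from compound 1 to compound 4 (0.70 log units; beyond the scatter), so among the four compounds shown, the two sulfonyl compounds, compound 3 and compound 4, sit apart from the two acyl compounds, compound 1 and compound 2, and none goes against this grouping. No measurement is at hand that accounts for these numbers.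

Open, as far as these compounds go, is whether an amine or a carboxylic acid on the phenyl group, or a longer chain on the sulfonyl sulfur, would shift the number away from that of compound 3 and compound 4. Also open, from the compounds shown here alone, is whether a carbamate or a urea on the amine nitrogen in a ring would fall with the sulfonyl compounds or with the acyl compounds.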